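The compounds below may be only part of what the source reports. "The series", "measured", "known", "first", "only" and "open" are said of these compounds alone.

Compound 1, `CC(C)/C=C/C(=O)Nc1cc2c(N3CCc4ccccc43)ncnc2cc1O[C@@H]1CCOC1`, gives 11200 nM in a functional assay on PC-3 cells (Homo sapiens) for antiproliferative activity, read by MTT assay, with a stated time of 72 h; a lower number here means a stronger inhibitor, a higher number a weaker inhibitor.
Compound 2, `COc1cc2ncnc(N3CCCc4ccccc43)c2cc1NC(=O)/C=C/C(C)C`, gives 8430 nM in this assay.
Compound 3, `CC(C)/C=C/C(=O)Nc1cc2c(N3CCCc4ccccc43)ncnc2cc1O[C@@H]1CCOC1`, gives 8510 nM in this assay.

All three numbers sit close together. Compound 3 stands second highest, with compound 2 nearest and compound 1 furthest, but both gaps are within the scatter: a 1.3-fold lower number from compound 1 to compound 3 (0.12 log units; within the scatter) and a 1.0-fold higher number from compound 2 to compound 3 (0.00 log units; within the scatter) describe changes at the amine on the shared core and at the ether on the shared core, and neither moves the number in a way that can be trusted.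

Compound 4, `CN(C)C/C=C/C(=O)Nc1cc2c(N3CCCc4ccccc43)ncnc2cc1O[C@@H]1CCOC1`, differs from compound 3 at the chain attached to the amide: (dimethylamino)methyl in place of isopropyl on a double-bonded chain carbon bound to a double-bonded chain carbon. Among the measured compounds shown here, no measured pair changes this chain, so neither measured step bears on it directly. The two steps that exist show that changes elsewhere on this core left the number where it was. With nothing pointing in either direction, compound 4 is expected to land near compound 3, with a step of a 1.4-fold lower number from compound 3 to compound 4 (0.15 log units; within the scatter) and a wide range allowed. Compound 4 is estimated at 6000 nM, between 1500 nM and 25000 nM.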

Compound 4, half-maximal inhibitory concentration: 4170 nM
Beside the measured number, compound 4's estimate is 1.4-fold (0.16 log units) above it; the measured number falls inside the stated range.
By their numbers in this assay, from the lowest: compound 4; then compounds 2, 3 and 1 (each within the scatter of the next).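

Of the steps shown, only the one at the chain attached to the amide lies beyond the scatter in this assay: (dimethylamino)methyl in place of isopropyl gives a 2.0-fold lower number from compound 3 to compound 4 (0.31 log units; beyond the scatter) and makes compound 4 the lowest number of the set. The earlier steps shown here, at the amine and the ether on the shared core, left the number within the scatter, so this chain is the one position here where a change has a readable effect, though a modest one. The change brings in a nitrogen, but nothing available explains why the number moves.

Still open, going by these compounds, is whether the nitrogen itself matters, which a piperidin-1-ylmethyl or morpholin-4-ylmethyl group, or a plain longer carbon chain, in the same place could help to settle. Also open, on these data alone, is whether the same change carries over to compound 2, with its methyl group on the oxygen.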